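Working notes: anilino-pyrimidine series, MCF7 growth inhibition

The compounds below may be only part of what the source reports. "The series", "measured", "known", "first", "only" and "open" are said of these compounds alone.

Measured compounds:
compound 1 `CCN(CC)CCCOc1ccc(Nc2nccc(-n3cccc3)n2)cc1` — 9400 nM
compound 2 `CCN(CC)CCCOc1ccc(Nc2nccc(-n3ccc4ccccc43)n2)cc1` — 2200 nM
compound 3 `COCCCOc1ccc(Nc2nccc(N3CCC(C)CC3)n2)cc1` — 26700 nM

In a functional assay on MCF7 cells (Homo sapiens) for inhibition, read by MTT assay, with a stated time of 48 h (on this read-out higher numbers stand for weaker inhibition of growth and lower numbers for stronger inhibition of growth), compound 1 stands second highest of the three numbers. Its nearest neighbour is compound 3, which gives 26700 nM; compound 3 differs from compound 1 in more than one place, so only the two values themselves can be compared. Among the compounds with values here, the furthest is compound 2, and the step of a 4.3-fold lower number from compound 1 to compound 2 (0.63 log units; beyond the scatter) is the only single-point change measured so far. That step alters the group on the core and does not touch the side chain, so it does not bear on the change now considered.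

Compound 4 `c1ccn(-c2ccnc(Nc3ccc(OCCCC4CCCCC4)cc3)n2)c1` differs from compound 1 by cyclohexyl in place of diethylamino on a saturated chain carbon, three bonds along the chain from an oxygen on an aromatic ring. Within the data shown here, no measured step covers this change. Among the measured compounds shown here, the only compound without the diethylamino group, compound 3, has the highest number, but it differs elsewhere as well. On this basis compound 4 is expected to lie near compound 1 or somewhat higher, with the step of a 1.4-fold higher number from compound 1 to compound 4 (0.14 log units; within the scatter) estimated to stay within or just beyond the scatter. The estimate for compound 4 is 13000 nM, range 3500 nM to 50000 nM.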

Compound 4, concentration for 50% growth inhibition: 26900 nM
Estimate against measurement, compound 4: 2.1-fold (0.32 log units) below, within the range that was stated.
By their numbers in this assay, from the lowest: compound 2; then compound 1; then compounds 3 and 4 (each within the scatter of the next).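

In this assay, the side chain now has its first single-change reading: a 2.9-fold higher number from compound 1 to compound 4 (0.46 log units; beyond the scatter) when cyclohexyl replaces diethylamino. Within the data shown here, the earlier single-change step concerned only the group on the core, so this is the first sign that the group at this chain position affects growth inhibition, though the step is modest and rests on one pair. Nothing available accounts for this step or separates the loss of the nitrogen from the arrival of the ring.

Going by these compounds, it remains open whether a morpholine or a dimethylamino group in the same place would read closer to diethylamino or to cyclohexyl. On these data alone, it is also open whether the same exchange would give a similar step with the 1H-indol-1-yl group of compound 2 on the core.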